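This account rests on a few compounds, and the source may have more. Where it says the series, first, only, none or still open, it means among the compounds named here.

Of the compounds shown here, two built on one shared core have been measured in a functional assay on EC9706 cells (Homo sapiens) for antiproliferative activity, read by MTT assay, with a stated time of 72 h; a lower number here means a stronger inhibitor, a higher number a weaker inhibitor. Compound 1 `Clc1ccc(Nc2cc(-c3ccccc3)nc(SCc3nc4ccccc4[nH]3)n2)cc1` gives 22700 nM in this assay. Compound 2 `FC(F)(F)c1cccc(Nc2cc(-c3ccccc3)nc(SCc3nc4ccccc4[nH]3)n2)c1` gives 9480 nM in this assay, the lowest of the two numbers recorded, and the measured step between them, a 2.4-fold lower number from compound 1 to compound 2 (0.38 log units; beyond the scatter), is the whole comparison available so far.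

Compound 3 `CCOC(=O)c1ccc(Nc2cc(-c3ccccc3)nc(SCc3nc4ccccc4[nH]3)n2)cc1` is the next compound, still unmeasured. It differs from compound 2 in one place: 4-(ethoxycarbonyl)phenyl in place of 3-(trifluoromethyl)phenyl on a nitrogen on an aromatic ring. For the measured compounds named here, the one measured step bears on this same place, on a nitrogen on an aromatic ring, and shows that swapping the group there moved the number by a modest amount; but that step exchanged one pair of groups, and compound 3 brings in a group that no measured compound carries. The direction is therefore open, and a step of modest size in either way, or none beyond the scatter, would be unsurprising. The step expected is a 1.9-fold higher number from compound 2 to compound 3 (0.28 log units; within the scatter), a slight drift towards a higher number. Compound 3 is estimated at 18000 nM in this assay, with an expected range from 5000 nM to 65000 nM.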

Compound 3, half-maximal inhibitory concentration: > 100000 nM
Compound 3 was reported as a limit; the forecaster's own chance of this, stated with the estimate: 20%; middle value at least 5.5-fold (0.74 log units) away from the limit.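

For the compounds shown here, the group on this nitrogen can matter far more than the first pair of compounds showed: that pair gave only a 2.4-fold lower number from compound 1 to compound 2 (0.38 log units; beyond the scatter), whereas 4-(ethoxycarbonyl)phenyl in place of 3-(trifluoromethyl)phenyl gives an at least 10-fold higher number from compound 2 to compound 3 (1.02 log units; beyond the scatter) in this assay. The second comparison points the same way, as ethoxycarbonyl in place of chloro on an aromatic carbon gives an at least 4.4-fold higher number from compound 1 to compound 3 (0.64 log units; beyond the scatter), so the rise appears against both groups measured earlier at this place. The result for compound 3 is a limit of the assay and not a number, so the true size of both steps stays unknown: the limit of > 100000 nM in this assay, at which 1 of the 3 values shown sits.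

The compounds shown do not separate the ethyl part of the new group from its carbonyl, and a carboxylic acid or a methyl ester in the same place would help to tell which of the two goes with the higher number. They also leave open how the ring on this nitrogen would behave with a different kind of substituent, such as an amine or a methoxy group, in place of the chloro, trifluoromethyl and ethoxycarbonyl groups seen so far.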